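A few compounds are considered here, and "the series" means these few. Any claim that something is new, unique, unknown or untested is made for them only; others in the source may bear on it.

In an ADME assay on HEK-293T cells (Homo sapiens) for inhibition, read by CCK-8 assay, with a stated time of 48 h, tested at 20 uM (a lower number here means less inhibition of growth, a higher number more inhibition of growth at the concentration tested), compound 3 `COc1ccc(S(=O)(=O)Oc2ccccc2/C=C(\C#N)C(=O)Nc2nnc(Cc3cccc(F)c3)s2)cc1` stands highest of the three measured compounds at 29%. Compound 1 `COc1ccc(Cc2nnc(NC(=O)/C(C#N)=C/c3ccccc3OS(=O)(=O)c3ccccc3[N+](=O)[O-])s2)cc1` gives 18% and compound 2 `N#C/C(=C\c1ccccc1OS(=O)(=O)c1ccccc1[N+](=O)[O-])C(=O)Nc1nnc(Cc2ccc(F)cc2)s1` gives 6%. Compound 4 `N#C/C(=C\c1ccccc1OS(=O)(=O)c1ccccc1[N+](=O)[O-])C(=O)Nc1nnc(Cc2cccc(F)c2)s1` departs from compound 3 by one change: 2-nitrophenyl in place of 4-methoxyphenyl on a sulfonyl sulfur. In short, 2-nitrophenyl replaces 4-methoxyphenyl on a sulfonyl sulfur.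

Going by the values given here, no measured step isolates this change. Among the compounds with values here, the only step available, a number 12 percentage points lower from compound 1 to compound 2 (beyond the scatter), is modest and concerns fluoro in place of methoxy on an aromatic carbon, so it bears only indirectly. More useful is that compound 1 and compound 2 both carry 2-nitrophenyl on the sulfonyl sulfur, and both lie lower in this assay than compound 3. Compound 2 at 6% also shares a fluoro substituent with compound 4, though the two are not identical. A moderate downward step is therefore expected, estimated as a number 17 percentage points lower from compound 3 to compound 4 (beyond the scatter). Compound 4 is expected at 12%, with an estimated range of 3% to 24%.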

Compound 4, percent growth inhibition at one concentration: "not toxic" (no number reported)
Nothing numeric was reported for compound 4, and the estimate cannot be compared.
By their numbers in this assay, from the lowest: compound 2; then compound 1; then compound 3.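

Going by these compounds alone, compound 4 is recorded in this assay only as "not toxic", without a number, and no step from compound 3 can be read. No available evidence bears on this result. Going by these compounds, the size of any shift on replacing 4-methoxyphenyl with 2-nitrophenyl on a sulfonyl sulfur remains open.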